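From methylsulfanyl to methylsulfonyl on the shared core

This account rests on a few compounds, and the source may have more. Where it says the series, first, only, none or still open, it means among the compounds named here.

In a functional assay on MCF7 cells (Homo sapiens) for antiproliferative activity, read by MTT assay, with a stated time of 24 h (on this read-out lower numbers stand for stronger inhibition and higher numbers for weaker inhibition), compound 3 (`CCN(CC)CCNC(=O)c1cc(C(CC)(CC)c2ccc(OCSC)c(C)c2)cn1CC`) gives 4640 nM. That lies within the scatter of compound 1 (`CCn1c(C(=O)NCCN)ccc1C(CC)(CC)c1ccc(OCS(=O)(=O)c2ccccc2)c(C)c1`) at 6470 nM, while compound 2 (`CCn1c(C(=O)N[C@H](C(=O)O)C(C)C)ccc1C(CC)(CC)c1ccc(OCS(=O)(=O)c2ccccc2)c(C)c1`) gives a clearly higher 24500 nM. Compound 4 (`CCN(CC)CCNC(=O)c1cc(C(CC)(CC)c2ccc(OCS(C)(=O)=O)c(C)c2)cn1CC`) carries methylsulfonyl in place of methylsulfanyl on a saturated chain carbon bound to an oxygen on an aromatic ring. Among the compounds with values here, the only measured step, a 3.8-fold higher number from compound 1 to compound 2 (0.58 log units; beyond the scatter), concerns an amide-type nitrogen and does not bear on this change, and no measured pair isolates it. No shift beyond the scatter is therefore expected in this assay. The estimated step is a 1.1-fold higher number from compound 3 to compound 4 (0.03 log units; within the scatter). Compound 4 is expected at 5000 nM, within an estimated range of 2000 nM to 13000 nM.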

Compound 4, half-maximal inhibitory concentration: 16300 nM
Compound 4: the middle estimate sits 3.3-fold (0.51 log units) below what was measured, outside the stated range (above it).
By their numbers in this assay, from the lowest: compounds 3 and 1 (each within the scatter of the next); then compounds 4 and 2 (each within the scatter of the next).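

In this assay, the position on a saturated chain carbon bound to an oxygen on an aromatic ring proves sensitive to the oxidation state of its sulfur group: methylsulfonyl in place of methylsulfanyl gives a 3.5-fold higher number from compound 3 to compound 4 (0.55 log units; beyond the scatter) in the shared core. Within the data shown here, this is the first measured step at this place, and it goes towards weaker inhibition. No evidence on the cause of this shift is available.

As far as these compounds go, whether methylsulfinyl at this place would give a number between those of compound 3 and compound 4 stays open. So does whether a longer chain on the sulfur, such as ethylsulfonyl, would follow the same direction.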